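Chain amine methylation at the aryl ether tail

The compounds below may be only part of what the source reports. "The series", "measured", "known", "first", "only" and "open" are said of these compounds alone.

Going by the values given here, compound 1 `CN(Cc1ccc(OCCCN)cc1)c1nc2ccc(Oc3ccc(C#N)cc3)cc2s1` gives 65000 nM in an assay on SH-SY5Y cells for inhibition of Voltage-dependent N-type calcium channel subunit alpha-1B (Homo sapiens), read by FLIPR and calcium flux, with stated times of 600 s and 300 s, in the presence of a further agent that is not named here (a lower number here means a stronger inhibitor, a higher number a weaker inhibitor), and stands lowest of the two numbers so far; nearest is compound 2 `CN(Cc1ccc(OCCCN)cc1)c1nc2ccc(Oc3ccc(C(F)(F)F)cc3)cc2s1` with 283000 nM, the step of a 4.4-fold higher number from compound 1 to compound 2 (0.64 log units; beyond the scatter) being trifluoromethyl in place of cyano on an aromatic carbon. Compound 3 `CN(C)CCCOc1ccc(CN(C)c2nc3ccc(Oc4ccc(C#N)cc4)cc3s2)cc1` differs from compound 1 by dimethylamino in place of amino on a saturated chain carbon, three bonds along the chain from an oxygen on an aromatic ring. Among the compounds with values here, no measured step touches the chain amine; the only recorded step sits on an aromatic carbon and does not bear on this change. Within the data shown here, with no precedent, a step within the scatter is expected, so compound 3 is estimated at 65000 nM (range 20000 nM to 200000 nM), corresponding to no change at the digits printed from compound 1 to compound 3 (within the scatter).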

Compound 3, half-maximal inhibitory concentration: 69000 nM
The estimate for compound 3 lay 1.1-fold (0.03 log units) below the measured number; the range from low to high includes it.
By their numbers in this assay, from the lowest: compounds 1 and 3 (each within the scatter of the next); then compound 2.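

Going by these compounds alone, the step of a 1.1-fold higher number from compound 1 to compound 3 (0.03 log units; within the scatter) in this assay is dimethylamino in place of amino at the chain end, the first reading at this position. Going from 1 hydrogen-bond donor on amino to 0 on dimethylamino, with 2 more carbons, leaves the number within the scatter for this cyano-bearing pair. No available evidence bears on this result.

As far as these compounds go, whether other groups are accepted at this chain end, such as a carboxylic acid or a morpholine ring, stays open. So does the effect of a longer chain between the oxygen and the amine.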